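The source may report more compounds than this note shows. Statements on the series, on what has been measured and on what is new or still open speak of the compounds shown alone.

Compound 1 `COc1ccc(OC(=O)c2cn(-c3ccccc3)nc2-c2ccncc2)cc1` and compound 2 `Cc1ccc(C(C)C)c(OC(=O)c2cn(-c3ccccc3)nc2-c2ccncc2)c1` share one core and differ only in the group on an oxygen next to a carbonyl group. In a functional assay on MDA-MB-231 cells (Homo sapiens) for cytotoxicity, read by MTT assay, with a stated time of 48 h (a lower number here means a stronger inhibitor, a higher number a weaker inhibitor), compound 1 gives > 100000 nM, which is a limit of the assay and not a number. In this assay compound 2 likewise gives > 100000 nM, again a limit. The step that the two limits leave unreadable from compound 1 to compound 2 therefore cannot be read, its size hidden by the limit of > 100000 nM in this assay, at which 2 of the 2 values shown sit. Compound 2 thus stands at the limit of this assay, with no number of its own and no readable step leading to it.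

Compound 3 `O=C(Oc1ccc2ccccc2c1)c1cn(-c2ccccc2)nc1-c1ccncc1` has not yet been measured in this assay. It differs from compound 2 by naphthalen-2-yl in place of 2-isopropyl-5-methylphenyl on an oxygen next to a carbonyl group. Among the measured compounds shown here, only the step from compound 1 to compound 2 bears on this change, and that step is unreadable, so neither direction nor size can be taken from it. Compound 3 is therefore expected to sit at the limit once more, and the step of a number no higher from compound 2 to compound 3 (the limit leaves the size open) is expected to be none beyond the scatter. The estimate for compound 3 in this assay is 100000 nM, expected to lie between 30000 nM and 300000 nM.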

Compound 3, half-maximal inhibitory concentration: > 100000 nM
Compound 3 gave a limit, no number; the forecaster's own chance of this, stated with the estimate: 75%; the middle value sits exactly at the limit.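

Compound 3, like compound 1 and compound 2, gives only a limit and no number in this assay, so no step among these three compounds can be read: the limit of > 100000 nM in this assay, at which 3 of the 3 values shown sit.

The compounds shown leave open whether the 4-methoxyphenyl, 2-isopropyl-5-methylphenyl and naphthalen-2-yl groups differ at all in this assay, and whether any group at this place on the shared core gives a readable number there.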